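A few compounds are considered here, and "the series" means these few. Any claim that something is new, unique, unknown or untested is made for them only; others in the source may bear on it.

Working notes on the series. Compound 1 `COc1ccccc1C(C1=C(O)C(=O)c2ccccc2C1=O)c1c[nH]c2ccccc12` in a functional assay on ECa-109 cells (Homo sapiens) for cytotoxicity, read by MTT assay, with a stated time of 48 h (on this read-out higher numbers stand for weaker inhibition and lower numbers for stronger inhibition), gives only a limit, > 200000 nM. Compound 2 `O=C1C(O)=C(C(c2ccc([N+](=O)[O-])cc2)c2c[nH]c3ccccc23)C(=O)c2ccccc21` in this assay gives 60900 nM, the only number shown for the series. Within the data shown here, the single measured step, an at least 3.2-fold lower number from compound 1 to compound 2 (0.51 log units; beyond the scatter), concerns the group on the saturated chain carbon and says nothing about the five-membered ring.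

Compound 3 `O=C1C(O)=C(C(c2ccc([N+](=O)[O-])cc2)c2c(-c3ccccc3)[nH]c3ccccc23)C(=O)c2ccccc21` is not yet measured. It differs from compound 2 by phenyl in place of hydrogen on an aromatic carbon. No measured step touches that position, so no shown step bears on this change, and the size of its effect cannot be read from the data. The expectation for the step of a 1.2-fold lower number from compound 2 to compound 3 (0.09 log units; within the scatter) is accordingly one of no change beyond the scatter, held loosely. Compound 3 is estimated at 50000 nM, with a range from 15000 nM to 150000 nM.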

Compound 3, half-maximal inhibitory concentration: 5080 nM
Compound 3: the middle estimate sits 9.8-fold (0.99 log units) above what was measured; the whole stated range lies above it.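

Among these compounds, the aromatic carbon of the five-membered aromatic ring, next to the ring nitrogen, is the one position no earlier step touched, and it proves sensitive in this assay: phenyl in place of hydrogen gives a 12-fold lower number from compound 2 to compound 3 (1.08 log units; beyond the scatter). Both ends of this step are numbers rather than limits, so its size can be read in full, though only with 4-nitrophenyl on the saturated chain carbon. Nothing shown gives a reason for the step.

As far as these compounds go, whether an aromatic ring is needed on this carbon stays open, since methyl or a longer chain there would separate a ring from any other carbon group. Also open, from the compounds shown here alone, are whether an amine or a carboxylic acid on the entering phenyl would keep the lower number, and whether the step recurs with 2-methoxyphenyl on the saturated chain carbon.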